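Working notes: amine substituent variation, one compound pending

The source may report more compounds than this note shows. Statements on the series, on what has been measured and on what is new or still open speak of the compounds shown alone.

Measured so far:
compound 1 `CC(C(=O)NCc1ccc(C(F)(F)F)nc1NCC1CCN(C(=O)OC(C)(C)C)CC1)c1ccc(NS(C)(=O)=O)c(F)c1` gives 1140 nM
compound 2 `CC(C(=O)NCc1ccc(C(F)(F)F)nc1Nc1ccccc1)c1ccc(NS(C)(=O)=O)c(F)c1` gives 1400 nM

Both numbers come from a functional assay on CHO-K1 cells for antagonist activity at transient receptor potential cation channel subfamily V member 1 (Homo sapiens), read by FLIPR; a lower number here means a stronger inhibitor, a higher number a weaker inhibitor. For the measured compounds named here, compound 2 has the higher of the two numbers, but its nearest neighbour, compound 1, sits only a little lower, and that gap lies within the scatter of this assay, so the two compounds are not told apart here; no step between them is worked out, and only their two values are known.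

Compound 3 `CC(C(=O)NCc1ccc(C(F)(F)F)nc1NCc1cccnc1)c1ccc(NS(C)(=O)=O)c(F)c1` is not yet measured. Its difference from compound 2 is (pyridin-3-yl)methyl in place of phenyl on a nitrogen on an aromatic ring. With compound 1 and compound 2 giving near-identical numbers despite quite different groups on the same nitrogen, there is no trend in this set that would point the change in either direction. The expected step from compound 2 to compound 3 is therefore small, a 1.4-fold lower number from compound 2 to compound 3 (0.15 log units; within the scatter), and likely not beyond the scatter. For compound 3 the estimate in this assay is 1000 nM, with a range from 300 nM to 3500 nM.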

Compound 3, half-maximal inhibitory concentration: "not active" (no number reported)
Compound 3 has no reported number here; no gap can be computed for the estimate.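

In this assay, for the compounds shown here, compound 3 is reported as "not active" (no number reported), so no step from compound 2 to compound 3, or any other new step, can be read. The compounds shown leave open how far compound 3 lies from compound 2, and which part of the change from anilino to ((pyridin-3-yl)methyl)amino matters. No available evidence bears on this result.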